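From Azide to Hydroxymethyl Triazole on a Shared Core

The source may report more compounds than this note shows. Statements on the series, on what has been measured and on what is new or still open speak of the compounds shown alone.

For the measured compounds named here, in a functional assay on A549 cells (Homo sapiens) for antiproliferative activity, read by MTT assay, with a stated time of 48 h (a lower number here means a stronger inhibitor, a higher number a weaker inhibitor), compound 2 `CC(C)=CCC[C@]1(C)/C=C/[C@@H](OC(=O)C=C(C)C)[C@](C)(O)/C=C/C(=O)/C(CN=[N+]=[N-])=C\C1` gives 1720 nM and holds the higher of the two numbers known so far, while compound 1 `CCN(CC)C/C1=C/C[C@](C)(CCC=C(C)C)/C=C/[C@@H](OC(=O)C=C(C)C)[C@](C)(O)/C=C/C1=O` gives 130 nM on the same core. Compound 3 `CC(C)=CCC[C@]1(C)/C=C/[C@@H](OC(=O)C=C(C)C)[C@](C)(O)/C=C/C(=O)/C(Cn2cc(CO)nn2)=C\C1` keeps that core and carries 4-(hydroxymethyl)-1H-1,2,3-triazol-1-yl in place of azido on a saturated chain carbon bound to a double-bonded ring carbon is the whole change. Going by the values given here, one measured step bears on this place, a 13-fold higher number from compound 1 to compound 2 (1.12 log units; beyond the scatter) and it is large and beyond the scatter, which shows that the group here can matter. That step involves diethylamino, however, and no triazole has been measured. No shift beyond the scatter is therefore expected, and the estimated step of a 1.2-fold higher number from compound 2 to compound 3 (0.07 log units; within the scatter) stays small. For compound 3 the estimate is 2000 nM with an expected range from 600 nM to 7000 nM in this assay here.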

Compound 3, half-maximal inhibitory concentration: 3470 nM
For compound 3 the middle estimate is 1.7-fold (0.24 log units) below the measured one; the range from low to high includes it.
By their numbers in this assay, from the lowest: compound 1; then compounds 2 and 3 (each within the scatter of the next).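

In this assay, 4-(hydroxymethyl)-1H-1,2,3-triazol-1-yl in place of azido gives a 2.0-fold higher number from compound 2 to compound 3 (0.30 log units; within the scatter) and so adds a five-membered aromatic ring at this place without a shift beyond the scatter. The same group in place of diethylamino gives a 27-fold higher number from compound 1 to compound 3 (1.43 log units; beyond the scatter) as a large step, so the gap from diethylamino now holds for two different replacements rather than azido alone. Nothing measured here explains that gap. The compounds shown leave open whether the diethylamino result extends to other amines, such as dimethylamino or morpholine. They also leave open whether a triazole carrying aminomethyl in place of hydroxymethyl would come closer to compound 1 on the shared core.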